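Tert-butoxy to methyl on compound 3

A few compounds are considered here, and "the series" means these few. Any claim that something is new, unique, unknown or untested is made for them only; others in the source may bear on it.

In a functional assay on MGC-803 cells (Homo sapiens) for inhibition, read by CCK-8 assay, with a stated time of 48 h (a lower number here means a stronger inhibitor, a higher number a weaker inhibitor), compound 1 `COc1cc(N(Cc2ccc(C)cc2)C(=O)CSC(=S)N2CCN(C(=O)OC(C)(C)C)CC2)cc(OC)c1OC` gives 16700 nM. Compound 2 `COc1ccc(CN(C(=O)CSC(=S)N2CCN(C(=O)OC(C)(C)C)CC2)c2cc(OC)c(OC)c(OC)c2)cc1C` reaches only a limit of the assay, > 20000 nM. Compound 3 `COc1ccc(CN(C(=O)CSC(=S)N2CCN(C(=O)OC(C)(C)C)CC2)c2cc(OC)c(OC)c(OC)c2)cc1O` gives 82 nM, the lowest number measured in the set.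

Compound 4 `COc1ccc(CN(C(=O)CSC(=S)N2CCN(C(C)=O)CC2)c2cc(OC)c(OC)c(OC)c2)cc1O` differs from compound 3 by methyl in place of tert-butoxy on a carbonyl carbon, a change from tert-butoxycarbonyl to acetyl: methyl in place of tert-butoxy on a carbonyl carbon. Going by the values given here, no measured step touches this place. The large steps of a 200-fold lower number from compound 1 to compound 3 (2.31 log units; beyond the scatter) and an at least 240-fold lower number from compound 2 to compound 3 (2.38 log units; beyond the scatter) arise in the aromatic group on the saturated chain carbon, as does an at least 1.1-fold higher number from compound 1 to compound 2 (0.07 log units; that floor lies within the scatter). They bear on the new change only indirectly, showing that one substitution can move the number strongly in this small set. Compound 3, at 82 nM, stands alone at the low end, so a moderate move towards a higher number is expected. The expected change is a 3.7-fold higher number from compound 3 to compound 4 (0.56 log units; beyond the scatter). For compound 4 the estimated value is 300 nM, with an expected range from 60 nM to 3000 nM.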

Compound 4, half-maximal inhibitory concentration: 310 nM
Estimate against measurement, compound 4: 1.0-fold (0.01 log units) below; the measured number falls inside the stated range.
By their numbers in this assay, from the lowest: compound 3; then compound 4; then compound 1. At a limit, above all of these: compound 2.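

Going by these compounds alone, the first step at this place, on a carbonyl carbon whose other neighbour is an amide-type nitrogen in a ring, is a 3.8-fold higher number from compound 3 to compound 4 (0.58 log units; beyond the scatter) in this assay, so the number responds to this group as well as to the aromatic group on the saturated chain carbon. Replacing tert-butoxy, with 5 heavy atoms, by methyl, with 1, moves the number much less than the change in that aromatic group, a 200-fold lower number from compound 1 to compound 3 (2.31 log units; beyond the scatter), and the hydroxy for methyl swap, an at least 240-fold lower number from compound 2 to compound 3 (2.38 log units; beyond the scatter). Nothing given here accounts for the step at the carbonyl carbon.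

The compounds shown leave open how an ethoxy, a longer chain such as propyl, or a phenyl on this carbonyl carbon would read. They also leave open whether tert-butoxycarbonyl to acetyl moves the number by a similar size when 4-methylphenyl replaces 3-hydroxy-4-methoxyphenyl.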